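Swapping methoxy for methylsulfanyl on a nucleoside core

The compounds below may be only part of what the source reports. "The series", "measured", "known", "first", "only" and "open" are said of these compounds alone.

Compound 1 `C#Cc1cn([C@@H]2O[C@H](CO)[C@@H](O)[C@H]2O)c2ncnc(OC)c12` was tested in a functional assay on CEM-DNR-bulk cells (Homo sapiens), read by MTT assay, with a stated time of 72 h (a lower number here means a stronger inhibitor, a higher number a weaker inhibitor), where compound 1 gives 3490 nM. Compound 2 `COc1ncnc2c1c(-c1cc3ccccc3o1)cn2[C@@H]1O[C@H](CO)[C@@H](O)[C@H]1O` gives 10800 nM in this assay. Compound 3 `COc1ncnc2c1c(-c1ccoc1)cn2[C@@H]1O[C@H](CO)[C@@H](O)[C@H]1O` reaches only the limit of this assay, > 20000 nM. Of the two numbers actually obtained, compound 1 stands lowest, as the step of a 3.1-fold higher number from compound 1 to compound 2 (0.49 log units; beyond the scatter) shows. Compound 4 `C#Cc1cn([C@@H]2O[C@H](CO)[C@@H](O)[C@H]2O)c2ncnc(SC)c12` differs from compound 1 by a single change: methylsulfanyl in place of methoxy on an aromatic carbon. Within the data shown here, the measured steps all concern the ethynyl group rather than the methoxy, so none of them speaks directly to this change; they show only that replacing the ethynyl group moved the number by moderate amounts, as in a 3.1-fold higher number from compound 1 to compound 2 (0.49 log units; beyond the scatter) and an at least 5.7-fold higher number from compound 1 to compound 3 (0.75 log units; beyond the scatter). For the present change a step no larger than those is therefore expected, in either direction, and possibly none beyond the scatter. Compound 4 is expected to give about 2500 nM in this assay, within a range from 600 nM to 12000 nM. That estimate means an expected step of a 1.4-fold lower number from compound 1 to compound 4 (0.14 log units; within the scatter).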

Compound 4, half-maximal inhibitory concentration: 110 nM
Beside the measured number, compound 4's estimate is 23-fold (1.36 log units) above it; the whole stated range lies above it.
By their numbers in this assay, from the lowest: compound 4; then compound 1; then compound 2. At a limit, above all of these: compound 3.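

Methylsulfanyl in place of methoxy, on the aromatic carbon next to the ring nitrogen, has a large effect in this assay: the change gives a 32-fold lower number from compound 1 to compound 4 (1.50 log units; beyond the scatter). The earlier steps shown here all replaced the ethynyl group and moved the number only moderately, as in a 3.1-fold higher number from compound 1 to compound 2 (0.49 log units; beyond the scatter), so this position matters far more than those steps could suggest. Nothing shown here explains why sulfur in place of oxygen at this position has so large an effect.

As far as these compounds go, it remains open whether the lower number is particular to methylsulfanyl, or whether a longer chain such as ethylsulfanyl or an amine at the same place would also give it. From the compounds shown here alone, it is also open whether methylsulfanyl would lower the number as much when paired with the 1-benzofuran-2-yl group of compound 2 or the furan-3-yl group of compound 3.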